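Swapping the acetyl for a thioamide on the piperidine

The source may report more compounds than this note shows. Statements on the series, on what has been measured and on what is new or still open speak of the compounds shown alone.

Of the compounds shown here, two sharing one core have been measured so far. Compound 1 `COc1cc(N)c(Cl)cc1C(=O)N[C@H]1CCN(CCCn2cncn2)C[C@H]1OC` gives 1270 nM in an assay on COS-7 cells for displacement of a labelled ligand from 5-hydroxytryptamine receptor 4 (Homo sapiens), read by scintillation counting, with a stated time of 30 min; on this read-out higher numbers stand for weaker inhibition and lower numbers for stronger inhibition. For the measured compounds named here, compound 2 `COc1cc(N)c(Cl)cc1C(=O)N[C@H]1CCN(CC2CCN(C(C)=O)CC2)C[C@H]1OC` gives 592 nM in this assay, and the only change between them, 1-acetylpiperidin-4-yl in place of 2-(1H-1,2,4-triazol-1-yl)ethyl on a saturated chain carbon bound to an amine nitrogen in a ring, produced a 2.1-fold lower number from compound 1 to compound 2 (0.33 log units; beyond the scatter). Compound 2 therefore holds the lowest number of the two.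

Compound 3 `CCC(=S)N1CCC(CN2CC[C@H](NC(=O)c3cc(Cl)c(N)cc3OC)[C@H](OC)C2)CC1` keeps the whole of compound 2 except for one group: a group of 4 heavy atoms (3 carbon, 1 sulfur; no ring) in place of a group of 3 heavy atoms (2 carbon, 1 oxygen; no ring), on an amine nitrogen in a ring. The measured step concerns a different part of the molecule, the chain hanging from the ring amine, and says nothing about the group on the far piperidine nitrogen. Going by the values given here, no measured pair bears on this exchange, so the direction is open. The expected change in this assay from compound 2 to compound 3 is a 1.2-fold lower number from compound 2 to compound 3 (0.07 log units; within the scatter), a shift likely within the scatter. Compound 3 is expected to give about 500 nM, with a range from 180 nM to 1500 nM.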

Compound 3, half-maximal inhibitory concentration: 593 nM
Estimate against measurement, compound 3: 1.2-fold (0.07 log units) below, and the stated range covers the measured number.
By their numbers in this assay, from the lowest: compounds 2 and 3 (each within the scatter of the next); then compound 1.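

In this assay, the exchange on the amine nitrogen of the six-membered ring gives a 1.0-fold higher number from compound 2 to compound 3 (0.00 log units; within the scatter), so the acetyl group can give way to the larger sulfur-bearing group with no difference this read-out can detect. The step from the triazole-bearing compound gives a 2.1-fold lower number from compound 1 to compound 3 (0.33 log units; beyond the scatter), so the advantage first seen with compound 2 does not depend on the acetyl group and is kept when that group is replaced. Nothing available explains why the exchange leaves the number where it is.

On these data alone, the exchange makes two changes at once, adding carbon and putting sulfur where oxygen stood, so it remains open whether each change is harmless alone or whether their effects cancel; a propanoyl group or a thioacetyl group on the same nitrogen would separate the two. Also open, as far as these compounds go, is how far this tolerance reaches, for example to a methanesulfonyl group, a benzoyl group or a bare hydrogen on that nitrogen, none of which resembles the two groups compared here as closely as they resemble each other.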